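A few compounds are considered here, and "the series" means these few. Any claim that something is new, unique, unknown or untested is made for them only; others in the source may bear on it.

Measured in a functional assay on PC-3 cells (Homo sapiens) for inhibition, read by MTT assay, with a stated time of 48 h; a higher number here means a weaker inhibitor, a lower number a stronger inhibitor
compound 1 `COc1ccc(-c2coc3cc(OCCCCSC(=S)N4CCN(C(=O)OC(C)(C)C)CC4)ccc3c2=O)cc1` gives 4610 nM
compound 2 `COc1ccc(-c2coc3cc(OCCCSC(=S)N4CCN(C)CC4)ccc3c2=O)cc1` gives 2210 nM
compound 3 `COc1ccc(-c2coc3cc(OCCCSC(=S)N4CCN(C(=O)OC(C)(C)C)CC4)ccc3c2=O)cc1` gives 1970 nM

Compound 2 stands within the scatter of compound 3 and clearly under compound 1. Compound 4 `COc1ccc(-c2coc3cc(OCCCCBr)ccc3c2=O)cc1` is a large departure from compound 2: a group of 2 heavy atoms (1 carbon, 1 bromine; no ring) in place of a group of 10 heavy atoms (6 carbon, 2 nitrogen, 2 sulfur; one six-membered non-aromatic ring with 2 hetero atoms), on a saturated chain carbon, three bonds along the chain from an oxygen on an aromatic ring, so the ring at the chain end is gone. For the measured compounds named here, the one measured step, a 1.1-fold lower number from compound 2 to compound 3 (0.05 log units; within the scatter), keeps that ring and cannot show what losing it does. Compound 4 does share its longer chain with compound 1, which gives 4610 nM, so a higher number is expected, though only loosely. The estimated step is a 5.4-fold higher number from compound 2 to compound 4 (0.73 log units; beyond the scatter), toward a weaker inhibitor. For compound 4 the expected value is 12000 nM, with an estimated range from 3500 nM to 40000 nM.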

Compound 4, half-maximal inhibitory concentration: 55600 nM
Beside the measured number, compound 4's estimate is 4.6-fold (0.67 log units) below it; measured number above the stated range.
By their numbers in this assay, from the lowest: compounds 3 and 2 (each within the scatter of the next); then compound 1; then compound 4.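

In this assay the change gives a 25-fold higher number from compound 2 to compound 4 (1.40 log units; beyond the scatter) and leaves a much weaker inhibitor, so the core with a bromomethyl chain end does not keep the activity of compound 2. The group at this chain end therefore matters far more than the swap on its ring nitrogen, which gave a 1.1-fold lower number from compound 2 to compound 3 (0.05 log units; within the scatter) and stayed within the scatter. Nothing available here explains the loss. Still open, going by these compounds, is which part of the lost group counts, the ring or the sulfur-bearing link, and whether a plain amine at the chain end would do as well.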